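Amino in place of chloro: an unmeasured step

The source may report more compounds than this note shows. Statements on the series, on what has been measured and on what is new or still open speak of the compounds shown alone.

Going by the values given here, compound 2 `CCn1cc(-c2nc3ccc(Cl)cc3[nH]2)c(=O)c2cc(F)c(N3CCNCC3)cc21` is the one compound of the pair with a number in a functional assay on U-937 cells (Homo sapiens) for cytotoxicity, read by sulforhodamine B assay, with a stated time of 48 h; a higher number here means a weaker inhibitor, a lower number a stronger inhibitor: there compound 2 gives 4200 nM. Compound 1 `CCn1cc(-c2nc3ccccc3[nH]2)c(=O)c2cc(F)c(N3CCNCC3)cc21` gives > 10000 nM, a limit and not a number. Compound 1 thus sits at the limit of > 10000 nM in this assay, at which 1 of the 2 values shown sits. Among the compounds with values here, the one measured step, an at least 2.3-fold lower number from compound 1 to compound 2 (0.37 log units; beyond the scatter), therefore runs from a limit to a number and sets only a floor on its own size.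

Compound 3 `CCn1cc(-c2nc3ccc(N)cc3[nH]2)c(=O)c2cc(F)c(N3CCNCC3)cc21` differs from compound 2 by amino in place of chloro on an aromatic carbon. No measured step covers an amino at this place; the only step shown concerns chloro entering in place of hydrogen, and it says nothing about what happens when chloro is replaced by another group. With compound 1 at its limit and compound 2 carrying the group that gave the lower number, removal of chloro leaves the outcome open, with the weight of the evidence pointing toward a higher number rather than a lower one. The expectation for compound 3 is a step of a 1.7-fold higher number from compound 2 to compound 3 (0.22 log units; within the scatter), modest at most. Compound 3 is thus estimated at 7000 nM, with a range from 2500 nM to 20000 nM.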

Compound 3, half-maximal inhibitory concentration: > 10000 nM
Compound 3: only a limit was reported; the forecaster's own chance of this, stated with the estimate: 35%; at least 1.4-fold (0.15 log units) between middle value and limit.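

Amino in place of chloro on this aromatic carbon gives an at least 2.3-fold higher number from compound 2 to compound 3 (0.37 log units; beyond the scatter), so in this assay the lower number of compound 2 does not carry over to a second group entering at this place, even though amino and chloro each count as one heavy atom. The position therefore responds to more than the presence of any substituent: of hydrogen, chloro and amino, only chloro has so far given a number, and the other two compounds rest at the same limit: the limit of > 10000 nM in this assay, at which 2 of the 3 values shown sit. The step from compound 1 to compound 3 cannot be read, since both values are limits, and hydrogen and amino therefore stay unordered in this assay.

Going by these compounds, it remains open whether the lower number belongs to chloro alone or extends to other groups on this carbon, such as fluoro, bromo, methyl, trifluoromethyl or methoxy, on the otherwise unchanged shared core. Also open, on these data alone, is whether an acylated amine or a carboxylic acid at this place would bring a compound back from the limit to a number in this assay.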